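The compounds below may be only part of what the source reports. "The series", "measured", "known", "first", "only" and "open" are said of these compounds alone.

- compound 1 `O=C(Nc1ccc(F)c(C(F)(F)F)c1)Nc1cnccn1`: < 1.6 ug/mL
- compound 2 `NC(=O)c1ccccc1NC(=O)Nc1ccc(F)c(C(F)(F)F)c1`: 1.6 ug/mL

Both compounds were tested in a physicochemical assay for solubility, read by nephelometry, in phosphate buffer, measured as kinetic solubility, at pH 6.5; on this read-out lower numbers stand for lower solubility and higher numbers for higher solubility. In this assay, compound 1 gives < 1.6 ug/mL, which is a limit of the assay and not a number. Its exact position is therefore unknown, and it stands at the limit of < 1.6 ug/mL in this assay, at which 1 of the 2 values shown sits. Compound 2 gives a true number, 1.6 ug/mL, and it shares the core of compound 1.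

Compound 3 `Cc1cc(NC(=O)Nc2ccc(F)c(C(F)(F)F)c2)on1` has not yet been measured. The change from compound 1 is 3-methyl-1,2-oxazol-5-yl in place of pyrazin-2-yl on an amide-type nitrogen. In words, it places 3-methyl-1,2-oxazol-5-yl in place of pyrazin-2-yl on an amide-type nitrogen, while the rest of the molecule stays the same. Among the measured compounds shown here, no measured pair shows what this exchange does, so any forecast is rough. For the measured compounds named here, the only guide is that compound 2, with the same core, reads 1.6 ug/mL, so a low reading is the sensible expectation. A small upward move is expected, estimated as an at least 1.5-fold higher number from compound 1 to compound 3 (0.19 log units; that floor lies within the scatter), and it may not clear the usual scatter. The assay may again report only a limit. For compound 3 the estimated value is 2.5 ug/mL, with an expected range from 1 ug/mL to 8 ug/mL.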

Compound 3, solubility: 6.3 ug/mL
Compound 3: middle estimate off by 2.5-fold (0.40 log units), on the low side; the range from low to high includes it.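

In this assay, putting 3-methyl-1,2-oxazol-5-yl in place of pyrazin-2-yl on the amide-type nitrogen gives an at least 3.9-fold higher number from compound 1 to compound 3 (0.59 log units; beyond the scatter), which shows that the reading responds to the group at this position. This happens even though the two groups match in the counts of heavy atoms, hydrogen-bond donors and hydrogen-bond acceptors, so those counts alone do not tell them apart here. Compound 1 stays at a limit of the assay, so the step marks only a minimum and its true size remains unknown: the limit of < 1.6 ug/mL in this assay, at which 1 of the 3 values shown sits.

From the compounds shown here alone, a single exchange cannot separate the part played by the five-membered aromatic ring from the part played by its methyl, so the source of the higher reading remains open. Going by these compounds, it is also open how far the reading would move with an amine or a carboxylic acid in place of that methyl, and whether such a change would add to the gain seen with compound 3 or cancel it.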